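The compounds below may be only part of what the source reports. "The series", "measured", "known", "first", "only" and "open" are said of these compounds alone.

Measured so far in a functional assay on RAW264.7 cells (Mus musculus) for cytotoxicity, read by MTT assay, with a stated time of 24 h; on this read-out lower numbers stand for stronger inhibition and higher numbers for weaker inhibition:
- Compound 1 `O=S(=O)(O)OCCCCCCCCCC[Te]c1ccccc1`: 5320 nM
- Compound 2 `O=S(=O)(O)OCCCCCCCCCCCC[Se]c1ccccc1`: > 100000 nM

Compound 2 has no exact number in this assay: its > 100000 nM is a limit of the assay.

The change to compound 3 `O=S(=O)(O)OCCCCCCCCCCC[Te]c1ccccc1` is a group of 7 heavy atoms (6 carbon, 1 tellurium; one six-membered aromatic ring of carbon only) in place of a group of 8 heavy atoms (7 carbon, 1 selenium; one six-membered aromatic ring of carbon only), on a saturated chain carbon, ten or more bonds along the chain from an oxygen. The group that enters contains tellurium, and compound 1 contains tellurium too. For the measured compounds named here, only two compounds have been measured, so no measured single change shows what this swap does. The expectation therefore rests on compound 1, which gives 5320 nM, and it points to compound 3 landing close to that value. The estimated step of an at least 16-fold lower number from compound 2 to compound 3 (1.22 log units; beyond the scatter) is large, well beyond the scatter, and runs toward stronger inhibition. For compound 3 the expected value is 6000 nM, with an estimated range of 1800 nM to 25000 nM.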

Compound 3, half-maximal inhibitory concentration: 7840 nM
Beside the measured number, compound 3's estimate is 1.3-fold (0.12 log units) below it; the range from low to high includes it.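

In this assay, for the compounds shown here, compound 3 gives a first comparison between two tellurium compounds with exact numbers. Having (sulfooxy)methyl in place of sulfooxy, on a saturated chain carbon, gives a 1.5-fold higher number from compound 1 to compound 3 (0.17 log units; within the scatter), so this change does not separate the two compounds. The swap from the selenium-bearing group to the tellurium-bearing group gives an at least 12-fold lower number from compound 2 to compound 3 (1.10 log units; beyond the scatter), but compound 2 has only a limit and not an exact number, so the full size of this step cannot be read: the limit of > 100000 nM in this assay, at which 1 of the 3 values shown sits.

This swap changes the heavy element and the carbon count of the group together, so the compounds shown cannot say which of the two matters. Also open, on these data alone, is how a carboxylic acid in place of the sulfooxy group, or a longer chain on a tellurium compound, would read here.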